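Cytotoxicity Check Before a Pyrimidine Replaces the Furan

The source may hold more compounds than are shown below. What is called first, only, known or untested is meant among the compounds shown, and "the series" means these compounds.

Compound 1, `Fc1ccc(-c2nn3c(NC4CCCC4)cccc3c2-c2cc(NC3CCCC3)ncn2)cc1`: in an ADME assay on Vero cells (Chlorocebus sabaeus) for cytotoxicity (a lower number here means that less compound is tolerated, a higher number that more compound is tolerated), compound 1 gives > 40000 nM, which is a limit of the assay rather than a number.
Compound 2, `Fc1ccc(-c2nn3c(NC4CCCC4)cccc3c2-c2ccoc2)cc1`: in this assay compound 2 gives "not determined" (no result reported).
Compound 3, `Fc1ccc(-c2nn3c(NC4CCCC4)cccc3c2-c2cccnc2NC2CCCC2)cc1`: in this assay compound 3 gives "not determined" (no result reported).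

Compound 2 therefore stands without any number of its own in this assay. Of the three entries shown, one further value is a limit and one further entry carries no number at all, so there is no measured step between any two compounds to lean on. The only quantitative anchor in the set is the limit of > 40000 nM in this assay, at which 1 of the 3 values shown sits, belonging to compound 1.

Compound 4, `Nc1nccc(-c2c(-c3ccc(F)cc3)nn3c(NC4CCCC4)cccc23)n1`, differs from compound 2 in a single place: 2-aminopyrimidin-4-yl in place of furan-3-yl on an aromatic carbon. Among the measured compounds shown here, with no measured step available, the expectation for compound 4 in this assay can rest only on the single limit seen for compound 1, and the anticipated step from compound 2 to compound 4 is none beyond the usual scatter, with a fair chance that the assay again returns only a limit. Compound 4 is expected to give about 40000 nM in this assay, estimated to fall between 12000 nM and 100000 nM.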

Compound 4, half-maximal cytotoxic concentration: 46000 nM
The estimate for compound 4 lay 1.2-fold (0.06 log units) below the measured number; measured number inside the range.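

In this assay, among the compounds shown here, compound 4 gives 46000 nM while compound 2 has no reported result, so no step from compound 2 to compound 4 can be read. The only other figure in the set is a limit: the limit of > 40000 nM in this assay, at which 1 of the 4 values shown sits. The compounds shown leave open whether replacing furan-3-yl with 2-aminopyrimidin-4-yl changes the tolerated concentration at all.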